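Notes on the aromatic methyl step from compound 1

A few compounds are considered here, and "the series" means these few. Any claim that something is new, unique, unknown or untested is made for them only; others in the source may bear on it.

Compound 1 `COC(=O)N1N=C(c2ccccc2)CC1c1cc(OC)c(OC)c(OC)c1`: 3950 nM
Compound 2 `CCCOC(=O)N1N=C(c2ccccc2)CC1c1cc(OC)c(OC)c(OC)c1`: > 10000 nM
Compound 3 `COC(=O)N1N=C(c2ccccc2)CC1c1ccc(OC)c(OC)c1`: 9150 nM

Within the data shown here, in a functional assay on HepG2 cells (Homo sapiens) for antiproliferative activity, read by MTT assay, with a stated time of 48 h (a lower number here means a stronger inhibitor of growth, a higher number a weaker inhibitor of growth), compound 1 gives 3950 nM, the lowest of the two numbers so far, and the nearest number is that of compound 3 at 9150 nM. Compound 2 gives > 10000 nM, which is a limit and not a number.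

The next compound is compound 4 `COC(=O)N1N=C(c2cccc(C)c2)CC1c1cc(OC)c(OC)c(OC)c1`, which changes phenyl to 3-methylphenyl on the core of compound 1: methyl in place of hydrogen on an aromatic carbon.

Neither measured step touches that phenyl group, so both bear on the change only indirectly. Hydrogen in place of methoxy on an aromatic carbon gave a 2.3-fold higher number from compound 1 to compound 3 (0.36 log units; beyond the scatter), and this is the closer precedent. Ethyl in place of hydrogen on a saturated chain carbon gave an at least 2.5-fold higher number from compound 1 to compound 2 (0.40 log units; beyond the scatter). Both changes to compound 1 raised the number, but two steps at other places set no firm rule. A slight rise is therefore expected in this assay, most likely not beyond the scatter.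

The expected change is a 1.3-fold higher number from compound 1 to compound 4 (0.10 log units; within the scatter). For compound 4 the estimate is 5000 nM, with an expected range of 2200 nM to 10000 nM.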

Compound 4, concentration for 50% growth inhibition: 980 nM
The estimate for compound 4 lay 5.1-fold (0.71 log units) above the measured number; the whole stated range lies above it.
By their numbers in this assay, from the lowest: compound 4; then compound 1; then compound 3. At a limit, above all of these: compound 2.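

In this assay, among these compounds, the phenyl group of compound 1 is the first place where a change lowers the number: a 4.0-fold lower number from compound 1 to compound 4 (0.61 log units; beyond the scatter). The two earlier changes, both made elsewhere on the molecule, went the other way, with an at least 2.5-fold higher number from compound 1 to compound 2 (0.40 log units; beyond the scatter) and a 2.3-fold higher number from compound 1 to compound 3 (0.36 log units; beyond the scatter), so a lower number is not something the series had shown before. A single added methyl, one heavy atom on an aromatic carbon of this six-membered ring, is enough to give a step beyond the scatter, which marks this phenyl group as a place where the number can fall, although nothing measured here bears on why it does.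

What the compounds shown leave open is whether the step belongs to methyl as such or would also appear with a chlorine atom, an amine or a longer chain on the same carbon. Also open, on these data alone, are whether the other carbons of that phenyl group respond in the same way, and whether the step would carry over to the core of compound 3, which has one methoxy fewer.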